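This account rests on a few compounds, and the source may have more. Where it says the series, first, only, none or still open, it means among the compounds named here.

Compound 1: `COc1cc2cc(Oc3ccc(NC(=O)Nc4cccc(C(F)(F)F)c4)cc3)c(C)nc2cc1OC` gives 3960 nM in a functional assay on HOP-92 cells (Homo sapiens) for inhibition, read by sulforhodamine B assay, with a stated time of 48 h; a lower number here means a stronger inhibitor of growth, a higher number a weaker inhibitor of growth.
Compound 2: `COc1cc2cc(Oc3ccc(NC(=O)Nc4ccc(Cl)c(C(F)(F)F)c4)cc3)c(C)nc2cc1OC` gives 2050 nM in this assay.

Compound 2 holds the lowest of the two numbers, and its nearest neighbour is compound 1. Going by the values given here, the single measured step, a 1.9-fold lower number from compound 1 to compound 2 (0.29 log units; within the scatter), put chloro in place of hydrogen on an aromatic carbon and stays within the scatter, so the two compounds cannot be ordered on these data.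

Compound 3, `COc1cc2cc(Oc3ccc(NC(=O)Nc4ccc(Cl)c(Cl)c4)cc3)c(C)nc2cc1OC`, has not yet been measured. Compared with compound 2 the change is chloro in place of trifluoromethyl on an aromatic carbon. Among the compounds with values here, no measured step exchanges trifluoromethyl for chloro; the only step on record touches a different aromatic carbon and is itself within the scatter. There is therefore nothing in the data pointing to a step beyond the scatter in this assay in either direction.

Compound 3 is accordingly expected to give 3000 nM, within a range from 1200 nM to 7500 nM. The step this estimate implies, a 1.5-fold higher number from compound 2 to compound 3 (0.17 log units; within the scatter), is expected to fall within the scatter.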

Compound 3, concentration for total growth inhibition: 4880 nM
The estimate for compound 3 lay 1.6-fold (0.21 log units) below the measured number; measured number inside the range.
By their numbers in this assay, from the lowest: compounds 2, 1 and 3 (each within the scatter of the next, the first and the last beyond it).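

In this assay, going by these compounds alone, the exchange of trifluoromethyl for chloro, on the carbon ortho to a chloro group and meta to a large group, gives the first step to clear the scatter, though only modestly: a 2.4-fold higher number from compound 2 to compound 3 (0.38 log units; beyond the scatter). With a chloro group already in place, this position therefore does not treat the two groups alike, and the lower number goes with trifluoromethyl, but the comparison of the other pair is weaker, as a 1.2-fold higher number from compound 1 to compound 3 (0.09 log units; within the scatter) leaves the 3,4-dichlorophenyl and 3-(trifluoromethyl)phenyl groups unordered. Nothing available bears on why the number moves at this position.

The compounds shown leave open whether a methyl, a methoxy or a nitrile on the same carbon would sit with trifluoromethyl or with chloro, or give a number outside that span. They also leave open whether the difference between compound 2 and compound 3 would persist with a group other than chloro, such as fluoro or methyl, on the neighbouring position named in their shared 4-chloro pattern.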